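This account rests on a few compounds, and the source may have more. Where it says the series, first, only, none or still open, it means among the compounds named here.

For the measured compounds named here, in a functional assay (Homo sapiens) for inhibition (a lower number here means a stronger inhibitor, a higher number a weaker inhibitor), compound 3 `CSc1ccc(CSc2nc(-c3ccc(Cl)cc3)c(-c3ccncc3)[nH]2)cc1` gives 2200 nM as the highest number of the three measured so far. Compound 1 `CSc1ccc(CSc2nc(-c3ccc(F)cc3)c(-c3ccncc3)[nH]2)cc1` stands at 670 nM and compound 2 `CS(=O)(=O)c1ccc(CSc2nc(-c3ccc(F)cc3)c(-c3ccncc3)[nH]2)cc1` at 330 nM so compound 3 is the weakest inhibitor of the set, with both gaps beyond the usual scatter. Compound 4 `CS(=O)(=O)c1ccc(CSc2nc(-c3ccc(Cl)cc3)c(-c3ccncc3)[nH]2)cc1` has not been measured yet and differs from compound 3 in one place: methylsulfonyl in place of methylsulfanyl on an aromatic carbon. The same swap gave a 2.0-fold lower number from compound 1 to compound 2 (0.31 log units; beyond the scatter) in the only case measured, a modest step. That pair carries fluoro where compound 3 carries chloro, and the change from fluoro to chloro alone gave a 3.3-fold higher number from compound 1 to compound 3 (0.52 log units; beyond the scatter) as another modest step. Going by the values given here, the swap has therefore been seen only with fluoro, and no measurement yet shows whether it behaves the same way with chloro. If it carries over, a modest step toward a lower number is expected in this assay at about the size seen with fluoro. The expected change is a 2.0-fold lower number from compound 3 to compound 4 (0.30 log units; within the scatter) on this reasoning. Compound 4 is estimated at 1100 nM with an expected range from 500 nM at the low end to 2400 nM at the high end.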

Compound 4, half-maximal inhibitory concentration: 320 nM
Compound 4: middle estimate off by 3.4-fold (0.54 log units), on the high side, and the stated range ends above it.
By their numbers in this assay, from the lowest: compounds 4 and 2 (each within the scatter of the next); then compound 1; then compound 3.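

In this assay the change from methylsulfanyl to methylsulfonyl has now been seen with both halogens, and its size depends on which halogen is present: with chloro it gives a 6.9-fold lower number from compound 3 to compound 4 (0.84 log units; beyond the scatter) and so is a larger step than with fluoro, which shows that the two changes do not simply add up: the same change on two cores in this assay, a 2.0-fold lower number (0.31 log units; beyond the scatter) from compound 1 to compound 2 and a 6.9-fold lower number (0.84 log units; beyond the scatter) from compound 3 to compound 4, 3.4-fold (0.53 log units) apart, beyond the scatter of two such steps.

Read the other way, chloro in place of fluoro gives a 1.0-fold lower number from compound 2 to compound 4 (0.01 log units; within the scatter) when methylsulfonyl is present, whereas it raised the number when methylsulfanyl was present: the same change on two cores in this assay, a 3.3-fold higher number (0.52 log units; beyond the scatter) from compound 1 to compound 3 and a 1.0-fold lower number (0.01 log units; within the scatter) from compound 2 to compound 4, 3.4-fold (0.53 log units) apart, beyond the scatter of two such steps.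

Among these four compounds, then, the group on this aromatic carbon decides whether swapping the halogen changes the number at all, and methylsulfonyl leaves the fluoro and chloro compounds level.

The compounds shown carry only two groups at this place and only two halogens, so it remains open whether the same dependence would appear with a carboxylic acid or an amine in place of methylsulfonyl, or with bromo or methyl in place of the halogen. The values also cannot tell why the two changes depend on each other.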